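The compounds below may be only part of what the source reports. "The series", "measured", "known", "first", "only" and "open" are said of these compounds alone.

Measured so far:
Compound 1, `O=C(Cn1c(-c2ccccc2)cc(-c2ccccc2)c1-c1ccco1)Nc1nc2ccccc2s1`, gives 89.9% in an ADME assay on HEK-293T cells (Homo sapiens) for cytotoxicity, read by MTT assay, with a stated time of 72 h, tested at 50 uM; on this read-out higher numbers stand for more inhibition at the one concentration tested (going by the name of the read-out) and lower numbers for less inhibition.
Compound 2, `O=C(Cn1c(-c2ccccc2)cc(-c2ccccc2)c1-c1ccccc1)Nc1nc2ccccc2s1`, gives 55% in this assay.

Compound 2 stands lowest of the two numbers shown, and the gap to the only other number is beyond the scatter. Among the compounds with values here, that gap is the single measured step, a number 34.9 percentage points lower from compound 1 to compound 2 (beyond the scatter), and it came from a change on an aromatic carbon of the shared core.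

Compound 3, `O=C(Cn1c(-c2ccccc2)cc(-c2ccccc2)c1-c1ccccc1)Nc1ccccn1`, has not yet been measured. Its change from compound 2 is pyridin-2-yl in place of 1,3-benzothiazol-2-yl on an amide-type nitrogen. Within the data shown here, this change sits on an amide-type nitrogen whose other neighbour is a carbonyl carbon, a different part of the molecule from the one altered in the measured step, so no measured step bears directly on it. The measured step therefore gives no guide to direction or size here, and the expectation rests on the value of compound 2 alone. The step implied by the estimate, a number 10 percentage points lower from compound 2 to compound 3 (within the scatter), is expected to be small and uncertain. Compound 3 is estimated at 45%, with a range from 15% to 75%.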

Compound 3, a percentage reported as inhibition, at one concentration (the size of the read-out at that concentration, not a potency): 62.9%
For compound 3 the middle estimate is 17.9 percentage points below the measured one; low and high end bracket the measured number.
By their numbers in this assay, from the lowest: compounds 2 and 3 (each within the scatter of the next); then compound 1.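

Within the data shown here, this is the first look at the amide-type nitrogen, and replacing 1,3-benzothiazol-2-yl with pyridin-2-yl there gives a number 7.9 percentage points higher from compound 2 to compound 3 (within the scatter) in this assay. Among these compounds, the group that enters is a single six-membered aromatic ring, while the group that leaves also carries a five-membered aromatic ring with a sulfur atom, so on this background that part of the molecule can be cut back without a readable difference at the one concentration tested; the earlier step on the aromatic carbon, a number 34.9 percentage points lower from compound 1 to compound 2 (beyond the scatter), remains the only step here that stands beyond the scatter. No measurement is at hand that explains either the lack of a readable difference or the earlier step.

Whether pyridin-2-yl gives a similar reading on the core of compound 1, which carries furan-2-yl, remains open, since that pairing is not among the compounds shown. Also open, from the compounds shown here alone, is how this nitrogen responds to a plain phenyl, which would keep the six-membered ring without its ring nitrogen, or to a non-aromatic group such as a cyclohexyl ring, an amine-bearing chain or a carboxylic acid.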